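Swapping a pyridine for a chlorophenyl on a cyanopyridone core

The compounds below may be only part of what the source reports. "The series", "measured", "known", "first", "only" and "open" are said of these compounds alone.

Measured compounds:
compound 1 `CCOC(=O)c1c(C)[nH]c(=O)c(C#N)c1-c1ccncc1`: 86.4%
compound 2 `CCOC(=O)c1c(C)[nH]c(=O)c(C#N)c1-c1ccc([N+](=O)[O-])cc1`: 95%
compound 3 `CCOC(=O)c1c(C)[nH]c(=O)c(C#N)c1-c1ccc([N+](=O)[O-])cc1[N+](=O)[O-]`: 99%

These three were tested in a functional assay on aorta (Rattus norvegicus) for inhibition; on this read-out higher numbers stand for larger maximal responses and lower numbers for smaller maximal responses. Compound 1 has the smallest of the three numbers: compound 2 lies within the usual scatter of it, while compound 3 lies beyond. Within the data shown here, the one measured single change, a number 4 percentage points higher from compound 2 to compound 3 (within the scatter), stays within the scatter.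

Compound 4 `CCOC(=O)c1c(C)[nH]c(=O)c(C#N)c1-c1cccc(Cl)c1` differs from compound 1 by 3-chlorophenyl in place of pyridin-4-yl on an aromatic carbon. Among the measured compounds shown here, no measured step swaps a pyridin-4-yl for a 3-chlorophenyl, so the nitro step offers only a loose hint that changing this ring leaves the maximal response high. A small rise, a number 3.6 percentage points higher from compound 1 to compound 4 (within the scatter), is therefore expected, within the scatter. Compound 4 is estimated at 90%, between 76% and 100%.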

Compound 4, largest response reached (reported as efficacy), in percent of the reference or control that the assay uses: 99%
Estimate against measurement, compound 4: 9 percentage points below; measured number inside the range.
By their numbers in this assay, from the lowest: compounds 1, 2, 3 and 4 (each within the scatter of the next, the first and the last beyond it).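

At this place on the shared core, opposite the ring nitrogen, the swap gives a number 12.6 percentage points higher from compound 1 to compound 4 (beyond the scatter) in this assay, the only single change shown that lies beyond the scatter. The ring at this position can therefore shift the maximal response, which the nitro step could not show. Nothing available explains this step.

On these data alone, it remains open whether the rise follows the loss of the ring nitrogen or the arrival of the chlorine: a plain phenyl here would separate the two. As far as these compounds go, how an amine or a carboxylic acid on this ring would read also remains unknown.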